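Hydrazone aryl series: bromine and hydroxyl on the benzylidene

The source may report more compounds than this note shows. Statements on the series, on what has been measured and on what is new or still open speak of the compounds shown alone.

Compound 1 `CN(C)CCn1cnnc1-c1cc(Oc2ccc(NC(=O)N/N=C/c3ccc(O)c(Br)c3)cc2F)ccn1`: in a functional assay on U-87MG ATCC cells (Homo sapiens) for cytotoxicity, read by MTT assay, with a stated time of 72 h (a higher number here means a weaker inhibitor, a lower number a stronger inhibitor), compound 1 gives 12400 nM.
Compound 2 `CN(C)CCn1cnnc1-c1cc(Oc2ccc(NC(=O)N/N=C/c3ccccc3)cc2F)ccn1`: in this assay compound 2 gives 2250 nM.
Compound 3 `CN(C)CCn1cnnc1-c1cc(Oc2ccc(NC(=O)N/N=C/c3cc(Br)c(O)c(Br)c3)cc2F)ccn1`: in this assay compound 3 gives > 100000 nM, a limit of the assay and not a number.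

Compound 3 stands at the weak end of the three, sitting at the limit of > 100000 nM in this assay, at which 1 of the 3 values shown sits. Compound 2 is the most potent of the set, since a 5.5-fold lower number from compound 1 to compound 2 (0.74 log units; beyond the scatter) and an at least 44-fold higher number from compound 2 to compound 3 (1.64 log units; beyond the scatter) are both beyond the scatter. The step of an at least 8.0-fold higher number from compound 1 to compound 3 (0.90 log units; beyond the scatter) shows that adding a second bromine pushes the number past the limit.

Compound 4 `CN(C)CCn1cnnc1-c1cc(Oc2ccc(NC(=O)N/N=C/c3ccc(O)cc3)cc2F)ccn1` is now to be measured. The change is 4-hydroxyphenyl in place of 3,5-dibromo-4-hydroxyphenyl on a carbon with a double bond to nitrogen. Both bromines leave while the hydroxyl stays. The relevant steps are an at least 8.0-fold higher number from compound 1 to compound 3 (0.90 log units; beyond the scatter), in which one bromine going in raised the number, and a 5.5-fold lower number from compound 1 to compound 2 (0.74 log units; beyond the scatter), in which stripping bromine and hydroxyl together lowered it. Removing both bromines from compound 3 is therefore expected to lower the number markedly, as an at least 20-fold lower number from compound 3 to compound 4 (1.30 log units; beyond the scatter), landing between compound 2 and compound 1. For compound 4 an estimated value of 5000 nM is expected, within 1500 nM to 20000 nM.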

Compound 4, half-maximal inhibitory concentration: 7750 nM
Estimate against measurement, compound 4: 1.6-fold (0.19 log units) below, within the range that was stated.
By their numbers in this assay, from the lowest: compound 2; then compounds 4 and 1 (each within the scatter of the next). At a limit, above all of these: compound 3.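

In this assay, 4-hydroxyphenyl in place of 3,5-dibromo-4-hydroxyphenyl gives an at least 12-fold lower number from compound 3 to compound 4 (1.11 log units; beyond the scatter), so the large change in this series goes with having both bromines on the aryl group, not with the hydroxyl that stays. The earlier step from 3-bromo-4-hydroxyphenyl to phenyl changed bromine and hydroxyl together, and compound 4 now separates them: the hydroxyl alone gives a 3.4-fold higher number from compound 2 to compound 4 (0.54 log units; beyond the scatter), while the single bromine gives a 1.6-fold lower number from compound 1 to compound 4 (0.20 log units; within the scatter), a difference within the scatter that cannot be read as an effect. Compound 3 stands at a limit of the assay and not at a number, so the full size of the change from removing its bromines stays a bound: the limit of > 100000 nM in this assay, at which 1 of the 4 values shown sits.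

The compounds shown leave open whether a methoxy, an amine or a carboxylic acid in place of the hydroxyl would raise the number as the hydroxyl does. They also leave open how a single bromine behaves on the aryl group without a hydroxyl, and whether a chloro or a methyl in place of the two bromines would give the same result as compound 3.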